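Replacing a urea with an amide on a shared core

The source may report more compounds than this note shows. Statements on the series, on what has been measured and on what is new or still open speak of the compounds shown alone.

Three compounds share one core and differ at its edges. Compound 1 `O=C(Nc1cccc(-n2cc(-c3ccncc3)c(-c3cc(O)cc(Cl)c3)n2)c1)Nc1ccc(Cl)c(C(F)(F)F)c1` carries a free hydroxyl on one ring; compound 2 `COc1cc(Cl)cc(-c2nn(-c3cccc(NC(=O)Nc4ccc(Cl)c(C(F)(F)F)c4)c3)cc2-c2ccncc2)c1` carries a methyl on that oxygen instead, and compound 3 `COc1cc(Cl)cc(-c2nn(-c3cccc(NC(=O)Nc4cc(C(F)(F)F)cc(C(F)(F)F)c4)c3)cc2-c2ccncc2)c1` has a different pattern of substituents on the far ring of the urea. In a functional assay on CCRF-CEM cells (Homo sapiens) for inhibition, read by sulforhodamine B assay, with a stated time of 48 h, tested at 0.01 uM (a higher number here means a weaker effect of the compound at the concentration tested, a lower number a stronger effect), compound 1 gives 97%, compound 2 gives 97%, and compound 3 gives 87%. Compound 2 is level with compound 1, and the gap down to compound 3 lies within the scatter, so all three read as weak at this concentration.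

Among the measured compounds shown here, the one measured step that changes a single place is no change at the digits printed from compound 1 to compound 2 (within the scatter), and it does not touch the urea. Compound 4 `COc1cc(Cl)cc(-c2nn(-c3cccc(NC(=O)c4cccc(C(F)(F)F)c4)c3)cc2-c2ccncc2)c1` differs from compound 2 in that urea: 3-(trifluoromethyl)phenyl in place of (4-chloro-3-(trifluoromethyl)phenyl)amino on a carbonyl carbon. For the measured compounds named here, no measured step alters this part of the molecule, so the only guide is that neither the oxygen substituent nor the far-ring pattern moved the read-out in this assay beyond the scatter.

Compound 4 is therefore expected to remain weak, with an estimated step of a number 2 percentage points lower from compound 2 to compound 4 (within the scatter) in this assay. The estimate for compound 4 is 95%, with a range from 80% to 105%.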

Compound 4, a percentage reported as activity, at one concentration (the size of the read-out at that concentration, not a potency): 96%
The estimate for compound 4 lay 1 percentage points below the measured number; the range from low to high includes it.
By their numbers in this assay, from the lowest: compounds 3, 4, 1 and 2 (each within the scatter of the next).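

In this assay, among the compounds shown here, the step to the amide, a number 1 percentage points lower from compound 2 to compound 4 (within the scatter), is the first measured change to reach the urea, and the read-out stays within the scatter. The group that leaves, (4-chloro-3-(trifluoromethyl)phenyl)amino, carries a hydrogen-bond donor and a chlorine, while the group that enters, 3-(trifluoromethyl)phenyl, carries neither, so at this single concentration, replacing the urea with an amide on the shared core leaves compound 4 just as weak as compound 2. Since all four compounds read as weak here, this flat result is not a measure of potency and cannot show that the urea is unimportant, and nothing available explains the outcome.

On these data alone, it remains open whether compound 2 and compound 4 would separate at a concentration where these compounds have a clear effect, since a comparison between two weak read-outs can hide a real difference. Also open, as far as these compounds go, is how the read-out would respond to a different group on the carbonyl carbon, such as a piperidine, which is an amine, or a longer chain such as hexyl.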